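The source may hold more compounds than are shown below. What is called first, only, known or untested is meant among the compounds shown, and "the series" means these compounds.

Compound 1 `Fc1ccc2ncnc(Nc3cccc(Cl)c3)c2c1` is the anchor of this small set: in a functional assay on HEK293 cells for antagonist activity at metabotropic glutamate receptor 5 (Rattus norvegicus), read by calcium flux (a higher number here means a weaker inhibitor, a lower number a stronger inhibitor), compound 1 gives 311 nM, the lowest of the two numbers reported. Its nearest neighbour is compound 3 `N#Cc1cccc(Nc2ncnc3ccc(F)cc23)c1`, which gives 1370 nM in this assay; the step is a 4.4-fold higher number from compound 1 to compound 3 (0.64 log units; beyond the scatter). Compound 2 `Fc1ccc2ncnc(Nc3cccc(C(F)(F)F)c3)c2c1` reaches only a limit in this assay, > 10000 nM, not a number; this is the limit of > 10000 nM in this assay, at which 1 of the 3 values shown sits. Read against compound 1 the step is an at least 32-fold higher number from compound 1 to compound 2 (1.50 log units; beyond the scatter). Between compound 2 and compound 3 the step is an at least 7.2-fold lower number from compound 2 to compound 3 (0.86 log units; beyond the scatter).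

Compound 4 `Fc1ccc2ncnc(Nc3cccc(Cl)c3F)c2c1` is the next compound in this assay. It differs from compound 1 by fluoro in place of hydrogen on an aromatic carbon. For the measured compounds named here, none of the measured steps bears directly on this change: each of them swaps the chloro group itself, while here the chloro group stays and a fluorine enters beside it. The expected step in this assay is therefore a 1.1-fold lower number from compound 1 to compound 4 (0.05 log units; within the scatter), within the scatter in either direction. For compound 4 the estimate in this assay is 280 nM. Its expected lower end is 90 nM and its expected upper end is 900 nM.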

Compound 4, half-maximal inhibitory concentration: 3720 nM
The estimate for compound 4 lay 13-fold (1.12 log units) below the measured number, outside the stated range (above it).
By their numbers in this assay, from the lowest: compound 1; then compound 3; then compound 4. At a limit, above all of these: compound 2.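

In this assay, for the compounds shown here, the position ortho to a chloro group proves sensitive, although the earlier compounds left it untouched: with the chloro group kept, fluoro in place of hydrogen on an aromatic carbon gives a 12-fold higher number from compound 1 to compound 4 (1.08 log units; beyond the scatter). The earlier steps shown here all exchanged the chloro group itself, so they spoke only to the choice of that group. This step shows that a change at a second place on the same six-membered aromatic ring, with the chloro group retained, also moves the number beyond the scatter.

No measurement shown gives a cause for this step. Open, on these data alone, is whether the step belongs to fluoro alone or to any group at this place, which a methyl, a methoxy or an amine there would test, and whether fluoro gives the same step when the chloro group is absent.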